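Swapping the benzyl substituent on the shared core

The source may report more compounds than this note shows. Statements on the series, on what has been measured and on what is new or still open speak of the compounds shown alone.

Compound 1 `CN(Cc1cc(C(F)(F)F)cc(C(F)(F)F)c1)C(=O)c1c(-c2ccccc2)c2ccccc2c(=O)n1C`: 1.2 nM
Compound 2 `Cc1ccccc1-c1c(C(=O)N(C)Cc2ccccc2Cl)n(C)c(=O)c2ccccc12`: 19 nM

In an assay on IM-9 cells for binding affinity to Substance-P receptor (Homo sapiens) (a higher number here means a weaker inhibitor, a lower number a stronger inhibitor), compound 2 gives 19 nM, the highest of the two numbers; compound 1 gives 1.2 nM, a gap beyond the scatter. Compound 3 `Cc1cc(C)cc(CN(C)C(=O)c2c(-c3ccccc3C)c3ccccc3c(=O)n2C)c1` differs from compound 2 in one place: 3,5-dimethylphenyl in place of 2-chlorophenyl on a saturated chain carbon bound to an amide-type nitrogen. A change of the benzyl group is also what separates compound 2 from compound 1, and there the number fell sharply. Compound 3 is therefore expected to show a moderate step down, a 3.8-fold lower number from compound 2 to compound 3 (0.58 log units; beyond the scatter), because compound 1 gives 1.2 nM with a different benzyl group. Compound 3 is estimated at 5 nM, between 1.5 nM and 15 nM.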

Compound 3, half-maximal inhibitory concentration: 32 nM
Beside the measured number, compound 3's estimate is 6.4-fold (0.81 log units) below it; measured number outside the range, above it.
By their numbers in this assay, from the lowest: compound 1; then compounds 2 and 3 (each within the scatter of the next).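

In this assay, exchanging 2-chlorobenzyl for 3,5-dimethylbenzyl gives a 1.7-fold higher number from compound 2 to compound 3 (0.23 log units; within the scatter). Going by these compounds alone, this pair isolates the benzyl group for the first time, and at this saturated chain carbon bound to an amide-type nitrogen, these two groups cannot be told apart. No measurement here explains this result.

From the compounds shown here alone, it remains open how a benzyl group carrying a methoxy group or a nitrile would read at this place. Going by these compounds, a longer chain between the amide-type nitrogen and the aromatic ring is equally open.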